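Aryl exchange from compound 1 to compound 3

This account rests on a few compounds, and the source may have more. Where it says the series, first, only, none or still open, it means among the compounds named here.

In a functional assay on PC-3 cells (Homo sapiens) for inhibition, read by sulforhodamine B assay (on this read-out higher numbers stand for weaker inhibition of growth and lower numbers for stronger inhibition of growth), compound 1 (`O=C(CCC1=CCCN(Cc2ccc(F)cc2)C1=O)NO`) gives "not determined" (no result reported) and so stands at no single number. Among the measured compounds shown here, the only measured neighbour is compound 2 (`COc1ccc(CN2CCC=C(CCC(=O)NO)C2=O)cc1`), which gives 7080 nM in this assay as the sole anchor for the series. Compound 3 (`Cc1cccc(CN2CCC=C(CCC(=O)NO)C2=O)c1`) departs from compound 1 by one exchange, 3-methylphenyl in place of 4-fluorophenyl on a saturated chain carbon bound to an amide-type nitrogen in a ring while the shared core stays unchanged. No measured step sizes this exchange, so no step beyond the scatter is expected in this assay, in either direction, from the level of compound 2 at 7080 nM in this read-out. Compound 3 is expected at 7000 nM with an estimated range of 2500 nM to 20000 nM in this series.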

Compound 3, concentration for 50% growth inhibition: > 10000 nM
Compound 3: only a limit was reported; the forecaster's own chance of this, stated with the estimate: 10%; middle value at least 1.4-fold (0.15 log units) away from the limit.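

In this assay compound 3 gives > 10000 nM, which is a limit. Among the compounds shown here, compound 1 gives "not determined" (no result reported), so no step to compound 3 can be read. The compounds shown leave open how 3-methylphenyl and 4-fluorophenyl compare in this assay.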